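Aromatic group back in place of cyclopentylmethyl

This account rests on a few compounds, and the source may have more. Where it says the series, first, only, none or still open, it means among the compounds named here.

Among the measured compounds shown here, compound 2 `O=C1N=C(O)S/C1=C\c1ccc(OCCC2CCCC2)cc1` gives 116 nM in an assay for inhibition of 15-hydroxyprostaglandin dehydrogenase [NAD(+)] (Homo sapiens), read by fluorescence and spectrophotometry (on this read-out lower numbers stand for stronger inhibition and higher numbers for weaker inhibition), the lowest of the two numbers measured so far. For the measured compounds named here, its only neighbour is compound 1 `O=C1N=C(O)S/C1=C\c1ccc(OCc2ccsc2)cc1`, which gives 429 nM in this assay. Going by the values given here, the single measured step, a 3.7-fold lower number from compound 1 to compound 2 (0.57 log units; beyond the scatter), is the only comparison available at the saturated chain carbon bound to an oxygen on an aromatic ring.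

Compound 3 `O=C1N=C(O)S/C1=C\c1ccc(OCc2ccc(CCl)cc2)cc1` differs from compound 2 by 4-(chloromethyl)phenyl in place of cyclopentylmethyl on a saturated chain carbon bound to an oxygen on an aromatic ring. An aromatic ring returns to the place from which compound 2 had removed one, so the measured step bears on this change in reverse: compound 2 gained over compound 1 by a modest amount beyond the scatter, and compound 3 is expected to give back part of that gain. Among the compounds with values here, the entering group is not the one carried by compound 1, so a full reversal is not assumed; the expected step is a 2.2-fold higher number from compound 2 to compound 3 (0.33 log units; beyond the scatter), a modest rise in the number.

The estimate for compound 3 in this assay is 250 nM, with a range from 90 nM to 700 nM.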

Compound 3, half-maximal inhibitory concentration: 124 nM
Estimate against measurement, compound 3: 2.0-fold (0.30 log units) above; the measured number falls inside the stated range.
By their numbers in this assay, from the lowest: compounds 2 and 3 (each within the scatter of the next); then compound 1.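

Working notes on the place on a saturated chain carbon bound to an oxygen on an aromatic ring: in this assay, the step of a 1.1-fold higher number from compound 2 to compound 3 (0.03 log units; within the scatter) does not separate 4-(chloromethyl)phenyl from cyclopentylmethyl, so an aromatic ring at this place does not in itself bring back the higher number of compound 1. The comparison with thiophen-3-yl now has a second member, with a 3.5-fold lower number from compound 1 to compound 3 (0.54 log units; beyond the scatter) standing beside a 3.7-fold lower number from compound 1 to compound 2 (0.57 log units; beyond the scatter) in the same direction, and among these three compounds only the thiophen-3-yl compound sits apart. Nothing on hand explains why thiophen-3-yl reads differently from the other two groups.

Still open is whether the chloromethyl group contributes anything of its own, since the compounds shown do not compare 4-(chloromethyl)phenyl with plain phenyl at this place. Also unsettled is how a phenyl carrying a carboxylic acid or an amine in place of the chloromethyl, or a longer chain leading to the cyclopentyl ring, would read in this assay at this same place.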